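Growth inhibition notes: from compound 2 to compound 4

The source may report more compounds than this note shows. Statements on the series, on what has been measured and on what is new or still open speak of the compounds shown alone.

In a functional assay on Caco-2 cells (Homo sapiens) for inhibition, read by MTT assay, with a stated time of 48 h, tested at 10 uM (a lower number here means less inhibition of growth, a higher number more inhibition of growth at the concentration tested), compound 2 `CCN(CC)Cc1c(O)c([C@H]2CCN(C)C[C@H]2O)c2oc(C)cc(=O)c2c1O` gives 17% and stands within the scatter of the other two measured compounds, compound 1 `COc1ccc(COc2cc(O)c3c(=O)cc(C)oc3c2[C@H]2CCN(C)C[C@H]2O)cc1` at 8% and compound 3 `Cc1cc(=O)c2c(O)c(CN3CCC(c4ccccc4)CC3)c(O)c([C@H]3CCN(C)C[C@H]3O)c2o1` at 21% so these three values are not separated. Among the measured compounds shown here, no measured pair differs in one place only, and the series therefore offers no direct measured guide to a single change.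

Compound 4 `CCOC(=O)N1CCN(Cc2c(O)c([C@H]3CCN(C)C[C@H]3O)c3oc(C)cc(=O)c3c2O)CC1` differs from compound 2 by 4-(ethoxycarbonyl)piperazin-1-yl in place of diethylamino on a saturated chain carbon bound to an aromatic carbon on the same kind of carbon, a saturated chain carbon bound to an aromatic carbon. The new group, 4-(ethoxycarbonyl)piperazin-1-yl, replaces diethylamino while the rest of the structure stays the same.

With compound 2 at 17% as the starting point and all three values in this assay within the scatter of one another, no step beyond the scatter is expected. The estimated a number 1 percentage points lower from compound 2 to compound 4 (within the scatter) lies within the scatter and carries no firm direction. Compound 4 is expected to read 16% with 5% to 30% as the estimated range.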

Compound 4, percent growth inhibition at one concentration: 18%
For compound 4 the middle estimate is 2 percentage points below the measured one; measured number inside the range.
By their numbers in this assay, from the lowest: compounds 1, 2, 4 and 3 (each within the scatter of the next, the first and the last beyond it).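

In this assay, the one-place pair now available reads as a number 1 percentage points higher from compound 2 to compound 4 (within the scatter), for 4-(ethoxycarbonyl)piperazin-1-yl in place of diethylamino on a saturated chain carbon bound to an aromatic carbon. This position therefore accepts a larger group, with a six-membered non-aromatic ring and more hydrogen-bond acceptors, without a step beyond the scatter at the concentration tested. No supporting measurement offers an explanation for this result.

Still open, on these data alone, is whether unsubstituted piperazin-1-yl, morpholin-4-yl or a chain ending in a carboxylic acid at this position would give a step beyond the scatter. Also open, as far as these compounds go, is whether the ethoxycarbonyl group contributes separately from the piperazine ring, as the pair changes both together.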